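The source may report more compounds than this note shows. Statements on the series, on what has been measured and on what is new or still open speak of the compounds shown alone.

Compound 1, `CC(=O)OCc1ccc2oc(=O)c(C(=O)Oc3cccc(Cl)c3)cc2c1`, in a functional assay on HT-1080 cells (Homo sapiens), read by transwell migration, with a stated time of 24 h, tested at 10 uM (a higher number here means a weaker effect of the compound at the concentration tested, a lower number a stronger effect), gives 6.17%.
Compound 2, `CC(=O)OCc1ccc2oc(=O)c(C(=O)Oc3cccc(Br)c3)cc2c1`, gives 11.8%.
Compound 3, `CC(=O)OCc1ccc2oc(=O)c(C(=O)Nc3cccc(Cl)c3)cc2c1`, gives 42.8%.

Among these three numbers compound 2 stands second highest. Its nearest neighbour is compound 1: a number 5.6 percentage points higher from compound 1 to compound 2 (within the scatter). Its furthest is compound 3: a number 31 percentage points higher from compound 2 to compound 3 (beyond the scatter). Among the compounds with values here, the only other step, a number 36.6 percentage points higher from compound 1 to compound 3 (beyond the scatter), also concerns the exchange of the ester for the amide, not the chain on the other side of the shared core.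

Compound 4, `CCC(=O)OCc1ccc2oc(=O)c(C(=O)Oc3cccc(Br)c3)cc2c1`, differs from compound 2 in one place: methyl in place of hydrogen on a saturated chain carbon bound to a carbonyl carbon. Within the data shown here, none of the measured steps touches this chain; the one within-scatter step swaps a halogen, and the two large steps swap the ester for an amide. There is thus no measured guide to this change, and the plain expectation is a step of no size beyond the scatter. Compound 4 is therefore estimated to give 14%, with a range from 4% to 35%, which is expected to mean a number 2.2 percentage points higher from compound 2 to compound 4 (within the scatter).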

Compound 4, a percentage reported as activity, at one concentration (the size of the read-out at that concentration, not a potency): 21.3%
Estimate against measurement, compound 4: 7.3 percentage points below; the range from low to high includes it.
By their numbers in this assay, from the lowest: compounds 1, 2 and 4 (each within the scatter of the next, the first and the last beyond it); then compound 3.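

In this assay the change from acetoxy to propanoyloxy gives a number 9.5 percentage points higher from compound 2 to compound 4 (within the scatter) and is the first step shown at this chain, as the earlier steps changed only the halogen or replaced the ester with the amide. With the 3-bromophenoxy ester in place, methyl in place of hydrogen on a saturated chain carbon bound to a carbonyl carbon therefore leaves the read-out within the usual scatter, though this rests on a single pair of compounds. No supporting measurement is available to interpret this step further.

The compounds shown leave open whether a longer chain, such as butanoyloxy, or an amine or a carboxylic acid at this place would also stay within the scatter. They also leave open whether the same methyl gives a step of like size with the 3-chlorophenoxy ester or the amide.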